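From compound 2 to compound 4: a cyclopropyl step

The source may hold more compounds than are shown below. What is called first, only, known or untested is meant among the compounds shown, and "the series" means these compounds.

- compound 1 `COc1ncc(-c2ccc3c(c2)N(c2ccc(C)cc2)C(=O)CO3)cc1NS(=O)(=O)c1ccc(F)cc1` gives 22700 nM as a measured value
- compound 2 `O=C1COc2ccc(-c3cccc(NS(=O)(=O)c4ccc(F)cc4)c3)cc2N1` gives > 40000 nM as a limit
- compound 3 `O=C1COc2ccc(-c3cnc4ccccc4c3)cc2N1C1CCCCC1` gives > 40000 nM as a limit

All three compounds were tested in a functional assay on HCT-116 cells (Homo sapiens) for antiproliferative activity, read by MTT assay, with a stated time of 72 h (on this read-out lower numbers stand for stronger inhibition and higher numbers for weaker inhibition), and only compound 1 has a true number. Compound 2 has only a limit and no number, which places it in this group: the limit of > 40000 nM in this assay, at which 2 of the 3 values shown sit, of the assay.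

Compound 4 `O=C1COc2ccc(-c3cccc(NS(=O)(=O)c4ccc(F)cc4)c3)cc2N1C1CC1` is compound 2 with cyclopropyl in place of hydrogen on an amide-type nitrogen in a ring. For the measured compounds named here, no measured pair shows this change alone. Compound 1 (22700 nM) carries a group on that nitrogen but also differs elsewhere. Compound 3 also carries a group there and stays at a limit (> 40000 nM). At most a small gain is therefore expected in this assay and another limit reading is quite possible. An estimated at least 1.1-fold lower number from compound 2 to compound 4 (0.05 log units; that floor lies within the scatter) is expected as the size of this step. The estimate for compound 4 is 35000 nM with an expected range of 15000 nM to 60000 nM for a measured number.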

Compound 4, half-maximal inhibitory concentration: > 40000 nM
Compound 4: only a limit was reported; the forecaster's own chance of this, stated with the estimate: 60%; middle value at least 1.1-fold (0.05 log units) away from the limit.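

Compound 2 and compound 4 each carry only a limit and no true number, and no step can be read between them. The compounds shown leave open whether cyclopropyl in place of hydrogen on that amide-type nitrogen changes the antiproliferative activity at all.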